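The source may report more compounds than this note shows. Statements on the series, on what has been measured and on what is new or still open speak of the compounds shown alone.

- compound 1 `OC(c1ncccc1F)C1(c2ccc(Cl)c(Cl)c2)CCC1`: 3000 mL/min/kg
- compound 2 `OC(c1ccccn1)C1(c2ccc(Cl)c(Cl)c2)COC1`: 417 mL/min/kg
- compound 3 `C[C@]1(c2ccc(OC(F)(F)F)cc2)C[C@@](O)(c2ccccn2)CO1`: 150 mL/min/kg

These three numbers come from an ADME assay on liver for metabolic stability, with Liver microsome (Rattus norvegicus) as the target, read by LC-MS, using microsomes, with a stated time of 5 h; a lower number here means slower removal, a higher number faster removal of the compound. Among them, compound 3 has the lowest number at 150 mL/min/kg. Compound 2 stands nearest at 417 mL/min/kg, and compound 1 stands furthest at 3000 mL/min/kg. Both gaps lie beyond the usual scatter of repeated measurements.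

The next compound to be measured is compound 4 `C[C@@]1(c2ccc(OC(F)(F)F)cc2)C[C@@](O)(c2ccccn2)CO1`. Its relation to compound 3 is simple to state: the two compounds have the same atoms and bonds and differ only in configuration as drawn: 1 of 2 stereo elements differ; a stereocentre at a saturated ring carbon is drawn R in compound 3 and S in compound 4. Nothing leaves and nothing enters, so this is purely a change in three-dimensional arrangement at a single centre, while the second stereo element stays as drawn.

For the measured compounds named here, no two measured compounds differ in only one place, so the data offer no direct measure of what such a change does in this assay. The expectation therefore starts from compound 3 at 150 mL/min/kg, and it allows for movement either way. Going by the values given here, a modest rise is the more likely direction, as nothing measured so far lies lower, but the step may well stay within the scatter. The expected change is small, a 1.3-fold higher number from compound 3 to compound 4 (0.10 log units; within the scatter). Compound 4 is estimated at 190 mL/min/kg, with an expected range of 70 mL/min/kg to 500 mL/min/kg.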

Compound 4, clearance: 333 mL/min/kg
Beside the measured number, compound 4's estimate is 1.8-fold (0.24 log units) below it; the measured number falls inside the stated range.
By their numbers in this assay, from the lowest: compound 3; then compounds 4 and 2 (each within the scatter of the next); then compound 1.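

In this assay, for the compounds shown here, there is now a first direct reading of a single change, a 2.2-fold higher number from compound 3 to compound 4 (0.35 log units; beyond the scatter), and this modest step lies beyond the usual scatter. The step can be placed on the saturated ring carbon, whose stereocentre is drawn R in compound 3 and S in compound 4, because nothing else separates the pair: the fact that compounds 3 and 4 differ only in the configuration as drawn. No atom leaves or enters, so this pair shows that the three-dimensional arrangement at this one centre can by itself shift the number, with the R form, compound 3, removed more slowly.

This is a single pair, so it cannot show whether the same reversal would move the number in the same direction, or by a similar amount, if a nitrile or a carboxylic acid stood in place of the trifluoromethoxy group. On these data alone, the effect of reversing the second stereocentre, which stays as drawn here, also remains open, as does the question of which part of either compound is attacked in the microsomes.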